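Benzyl for Cyclopentyl on the Amide Nitrogen of Compound 2

The source may hold more compounds than are shown below. What is called first, only, known or untested is meant among the compounds shown, and "the series" means these compounds.

Compound 1 `CCC[C@H](NC(=O)[C@@H]1C[C@@H]2CN1C(=O)[C@H](C1CCCC1)NC(=O)OCCCCCCc1cccc3c1CN(C3)C(=O)O2)C(=O)C(=O)CC1CC1` was tested in an ADME assay on Huh-7 cells (Homo sapiens) for cytotoxicity; on this read-out lower numbers stand for higher toxicity in this test and higher numbers for lower toxicity in this test. In this assay compound 1 reaches only the limit of > 50000 nM, not a number. Compound 2 `CCC[C@H](NC(=O)[C@@H]1C[C@@H]2CN1C(=O)[C@H](C(C)(C)C)NC(=O)OCCCCCCc1cccc3c1CN(C3)C(=O)O2)C(=O)C(=O)NC1CCCC1` carries a tert-butyl side chain in place of the cyclopentyl of compound 1 and an amide to cyclopentylamine at the terminus. In this assay compound 2 likewise gives only the limit of > 50000 nM. For the measured compounds named here, compound 2 therefore stands at the limit of > 50000 nM in this assay, at which 2 of the 2 values shown sit, and no measured step between the two compounds exists, so no size of change can be read from them. Compound 3 `CCC[C@H](NC(=O)[C@@H]1C[C@@H]2CN1C(=O)[C@H](C(C)(C)C)NC(=O)OCCCCCCc1cccc3c1CN(C3)C(=O)O2)C(=O)C(=O)NCc1ccccc1` differs from compound 2 by benzyl in place of cyclopentyl on an amide-type nitrogen. For compound 3 a step from compound 2 of a step that the limit leaves unreadable from compound 2 to compound 3 is expected, that is, none beyond the scatter. Compound 3 is accordingly estimated at 60000 nM, within a range of 30000 nM to 120000 nM, most likely again reported only as a limit.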

Compound 3, half-maximal cytotoxic concentration: > 50000 nM
Compound 3 was reported as a limit; the forecaster's own chance of this, stated with the estimate: 80%; the middle value lies beyond the limit too.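

Compound 3 gives > 50000 nM, which is a limit and not a number. For the compounds shown here, no step can therefore be read from compound 2 to compound 3. The compounds shown leave open how benzyl and cyclopentyl on the amide-type nitrogen truly compare in this assay.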